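Three Triazoles Measured, a Fourth Fluorophenyl Analogue Expected

The compounds below may be only part of what the source reports. "The series", "measured", "known", "first", "only" and "open" are said of these compounds alone.

Of the compounds shown here, three sharing one core have been tested in a functional assay on PC-12 cells (Rattus norvegicus) for cytotoxicity, read by MTT assay, with stated times of 2 h and 24 h, tested at 5 uM; a lower number here means a weaker effect, a higher number a stronger effect of the compound at the concentration tested. Compound 1 `CC(C)(C)c1ccc(-n2nc(-c3ccc(C(F)(F)F)cc3O)nc2-c2ccccc2O)cc1` gives 77.8% in this assay. Compound 2 `Oc1cc(C(F)(F)F)ccc1-c1nc(-c2ccccc2O)n(-c2ccc(F)cc2)n1` gives 86.7%. Compound 3 `Oc1cc(C(F)(F)F)ccc1-c1nc(-c2ccccc2O)n(-c2ccccc2C(F)(F)F)n1` gives 80%. Compound 3 thus stands with its number between those of the other two: the gap a number 2.2 percentage points higher from compound 1 to compound 3 (within the scatter) and the gap a number 6.7 percentage points lower from compound 2 to compound 3 (within the scatter) are both within the scatter, as is a number 8.9 percentage points higher from compound 1 to compound 2 (within the scatter).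

Compound 4 `Oc1cc(C(F)(F)F)ccc1-c1nc(-c2ccccc2O)n(-c2cccc(F)c2)n1` has not yet been measured. It differs from compound 3 in one place: 3-fluorophenyl in place of 2-(trifluoromethyl)phenyl on an aromatic nitrogen. The two steps that bear on this change are those that also swap the group on the aromatic nitrogen, namely a number 2.2 percentage points higher from compound 1 to compound 3 (within the scatter) and a number 6.7 percentage points lower from compound 2 to compound 3 (within the scatter), and neither moved the number beyond the scatter. A step of similar size is therefore expected here, with no direction that can be trusted, so that a number 2 percentage points higher from compound 3 to compound 4 (within the scatter) is the estimated change. Compound 4 is accordingly expected to give about 82%, most likely between 70% and 93%.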

Compound 4, a percentage reported as activity, at one concentration (the size of the read-out at that concentration, not a potency): 87.7%
Compound 4: the middle estimate sits 5.7 percentage points below what was measured; measured number inside the range.
By their numbers in this assay, from the lowest: compounds 1, 3, 2 and 4 (each within the scatter of the next).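

In this assay, 3-fluorophenyl in place of 4-fluorophenyl on the aromatic nitrogen gives a number 1 percentage points higher from compound 2 to compound 4 (within the scatter), so shifting the fluorine around this ring produces no change that can be told from scatter. The larger swaps behave the same way, with a number 7.7 percentage points higher from compound 3 to compound 4 (within the scatter) when 3-fluorophenyl replaces 2-(trifluoromethyl)phenyl and a number 9.9 percentage points higher from compound 1 to compound 4 (within the scatter) when it replaces 4-(tert-butyl)phenyl, so four differently substituted phenyl groups at this position now stand within the scatter of one another. Nothing available explains these numbers.

As far as these compounds go, all four compounds carry a substituted phenyl ring on this nitrogen, so it remains open whether an amine or a carboxylic acid on that ring, or a longer alkyl chain replacing it, would move the number beyond the scatter. The two hydroxy groups are also the same throughout, which leaves their part in the read-out unknown.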